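The source may hold more compounds than are shown below. What is called first, only, known or untested is meant among the compounds shown, and "the series" means these compounds.

Measured compounds:
compound 1, `O=C(O)CC1COc2cc(OCc3nnc(-c4ccccc4)s3)ccc21`, 3.36%
compound 2, `O=C(O)CC1COc2cc(OCc3cc(-c4ccccc4)on3)ccc21`, 0.84%
compound 3, `Cc1nc(-c2cc3ccccc3o2)sc1COc1ccc2c(c1)OCC2CC(=O)O`, 14.8%

All three were tested in a functional assay on CHO cells for agonist activity at Free fatty acid receptor 1 (Homo sapiens), read by FLIPR and calcium flux, tested at 100 nM; on this read-out lower numbers stand for a weaker effect and higher numbers for a stronger effect at the one concentration tested. Compound 3 stands highest of the three numbers: in this assay compound 3 gives 14.8%, and the nearest number, that of compound 1, lies beyond the usual scatter below it, while the furthest, that of compound 2, lies further below still. Compound 3 is therefore the most active of the three on this read-out.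

Compound 4, `Cc1nc(-c2cccc(F)c2)sc1COc1ccc2c(c1)OCC2CC(=O)O`, has not yet been measured in this assay. It differs from compound 3 in one place: 3-fluorophenyl in place of 1-benzofuran-2-yl on an aromatic carbon. For the measured compounds named here, no measured pair shows this change directly, so the expected step rests on what the three numbers show. Compounds 1 and 2, whose five-membered rings carry a plain phenyl group, both sit low in this assay, and the two lowest numbers belong to them. On that basis the step from compound 3 to compound 4 is expected to be a drop beyond the scatter, a number 8.8 percentage points lower from compound 3 to compound 4 (within the scatter). Compound 4 is thus expected to give about 6% in this assay, in a range from 0% to 18%.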

Compound 4, a percentage reported as activity, at one concentration (the size of the read-out at that concentration, not a potency): 56.9%
Beside the measured number, compound 4's estimate is 50.9 percentage points below it; the whole stated range lies below it.
By their numbers in this assay, from the lowest: compounds 2 and 1 (each within the scatter of the next); then compound 3; then compound 4.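

Replacing 1-benzofuran-2-yl with 3-fluorophenyl on the aromatic carbon of the five-membered ring with 1 nitrogen and 1 sulfur gives a number 42.1 percentage points higher from compound 3 to compound 4 (beyond the scatter) in this assay and so shows that the read-out depends strongly on the group at this position. It also shows that the two-ring 1-benzofuran-2-yl is not required at this position, since a single six-membered aromatic ring of carbon only gives the highest number of the four compounds. Nothing shown here explains this gain.

The compounds shown leave open whether the gain depends on the fluorine or would also appear with a plain phenyl, 3-chlorophenyl or 3-methoxyphenyl group on the same carbon. With one concentration tested, they also leave the potency of compound 4 open.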